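The compounds below may be only part of what the source reports. "The series", "measured", "known", "first", "only" and "open" are said of these compounds alone.

Compound 1 `N#Cc1cc(C#N)cc(-n2nnc(-c3ccccn3)n2)c1` gives 18 nM in an assay on cell membranes for binding affinity to metabotropic glutamate receptor 5 (Rattus norvegicus); on this read-out lower numbers stand for stronger inhibition and higher numbers for weaker inhibition. Compound 2 `N#Cc1cc(N)cc(-n2nnc(-c3ccccn3)n2)c1` gives 95 nM in this assay, which amounts to a 5.3-fold higher number from compound 1 to compound 2 (0.72 log units; beyond the scatter). For compound 3 `N#Cc1cc(OCc2ccccc2)cc(-n2nnc(-c3ccccn3)n2)c1` the assay reports only a limit, > 600 nM, so compound 3 stands at the limit of > 600 nM in this assay, at which 1 of the 3 values shown sits, rather than at a number. The steps leading to it read an at least 33-fold higher number from compound 1 to compound 3 (1.52 log units; beyond the scatter) and an at least 6.3-fold higher number from compound 2 to compound 3 (0.80 log units; beyond the scatter). Compound 4 `N#Cc1cc(Oc2cccnc2)cc(-n2nnc(-c3ccccn3)n2)c1` differs from compound 3 by pyridin-3-yl in place of benzyl on an oxygen on an aromatic ring. Within the data shown here, none of the measured steps touches the group on this oxygen; each replaces a cyano or an amino on the ring, so they say little about this exchange. Compound 4 is therefore expected to remain weak, with an estimated step that the limit leaves unreadable from compound 3 to compound 4 in this assay. The estimate for compound 4 is 1500 nM, expected to lie between 400 nM and 6000 nM.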

Compound 4, inhibition constant: 16 nM
Compound 4: the middle estimate sits 94-fold (1.97 log units) above what was measured; the whole stated range lies above it.
By their numbers in this assay, from the lowest: compounds 4 and 1 (each within the scatter of the next); then compound 2. At a limit, above all of these: compound 3.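

On an oxygen on an aromatic ring, the group decides the reading in this assay: pyridin-3-yl in place of benzyl gives an at least 37-fold lower number from compound 3 to compound 4 (1.57 log units; beyond the scatter). That step is only a bound, as compound 3 stands at a limit: the limit of > 600 nM in this assay, at which 1 of the 4 values shown sits. A ring on this oxygen can therefore keep the affinity of the cyano compound, with a 1.1-fold lower number from compound 1 to compound 4 (0.05 log units; within the scatter) and a 5.9-fold lower number from compound 2 to compound 4 (0.77 log units; beyond the scatter).

From the compounds shown here alone, it stays open whether the ring nitrogen or the loss of the benzyl carbon carries the change, which a phenyl on this oxygen would separate. Going by these compounds, how a pyridin-2-yl or pyridin-4-yl would read also stays open.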